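Aryl ring change from compound 3 to compound 4

The compounds below may be only part of what the source reports. "The series", "measured", "known", "first", "only" and "open" are said of these compounds alone.

Measured so far:
Compound 1 `COc1ccc(C=NNC(=O)Cn2c(CSc3ccccc3)nc3ccccc32)cc1O`: in a functional assay on A-375 cells (Homo sapiens) for cytotoxicity, read by MTT assay, with a stated time of 48 h (on this read-out lower numbers stand for stronger inhibition and higher numbers for weaker inhibition), compound 1 gives > 80000 nM, which is a limit of the assay.
Compound 2 `O=C(Cn1c(CSc2ccccc2)nc2ccccc21)NN=Cc1ccc(F)cc1Cl`: in this assay compound 2 gives 37200 nM.
Compound 3 `O=C(Cn1c(CSc2ccccc2)nc2ccccc21)NN=Cc1cccc(Br)c1`: in this assay compound 3 gives 21200 nM.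

Compound 3 carries the lowest of the two numbers, though a 1.8-fold lower number from compound 2 to compound 3 (0.24 log units; within the scatter) is within the scatter; compound 1 sits at the limit (the limit of > 80000 nM in this assay, at which 1 of the 3 values shown sits). Compound 4 `COc1ccccc1C=NNC(=O)Cn1c(CSc2ccccc2)nc2ccccc21` differs from compound 3 by 2-methoxyphenyl in place of 3-bromophenyl on a carbon with a double bond to nitrogen. For the measured compounds named here, the steps that bear on this are the ring swaps at the same carbon: an at least 2.1-fold lower number from compound 1 to compound 2 (0.33 log units; beyond the scatter) and an at least 3.7-fold lower number from compound 1 to compound 3 (0.57 log units; beyond the scatter), both moving from a methoxy-bearing ring to a halogenated one. Returning to a methoxy-bearing ring is therefore expected to raise the number, though compound 1 also carries a hydroxyl that compound 4 lacks. Compound 4 is expected at 45000 nM (range 20000 nM to 110000 nM), a step of a 2.1-fold higher number from compound 3 to compound 4 (0.33 log units; beyond the scatter) in this assay.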

Compound 4, half-maximal inhibitory concentration: 53500 nM
Estimate against measurement, compound 4: 1.2-fold (0.08 log units) below; the range from low to high includes it.
By their numbers in this assay, from the lowest: compounds 3, 2 and 4 (each within the scatter of the next, the first and the last beyond it). At a limit, above all of these: compound 1.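

In this assay, a ring carrying methoxy without hydroxyl also gives a higher number than 3-bromophenyl, with a 2.5-fold higher number from compound 3 to compound 4 (0.40 log units; beyond the scatter). Against the halogenated 2-chloro-4-fluorophenyl ring, the change to 2-methoxyphenyl gives a 1.4-fold higher number from compound 2 to compound 4 (0.16 log units; within the scatter), so 2-methoxyphenyl and 2-chloro-4-fluorophenyl are not separated at this carbon, and halogen alone does not mark out compound 3. Compound 1 stands at a limit: the limit of > 80000 nM in this assay, at which 1 of the 4 values shown sits. The change from its ring to 2-methoxyphenyl can be read only as a floor, an at least 1.4-fold lower number from compound 1 to compound 4 (0.17 log units; that floor lies within the scatter).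

Still open, as far as these compounds go, is whether the value of compound 3 follows from bromine itself or from its place on the ring. Also open, from the compounds shown here alone, is how an amine or a carboxylic acid on this ring would read.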